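This account rests on a few compounds, and the source may have more. Where it says the series, first, only, none or still open, it means among the compounds named here.

Measured so far:
compound 1 `CCOC(=O)CC(=O)N1CCSC1COc1ccccc1OC` — 11 mg/kg
compound 2 `COc1ccccc1OCC1SCCN1C(=O)CC(=O)NCc1ccccn1` — 64 mg/kg

In a functional assay on the whole organism (trachea) for inhibition, with Cavia porcellus as the target (on this read-out lower numbers stand for an effect already at smaller amounts and higher numbers for an effect only at larger amounts of compound), compound 1 gives 11 mg/kg and compound 2 gives 64 mg/kg. Within the data shown here, compound 2 therefore holds the highest of the two numbers; its only neighbour is compound 1, and the step of a 5.8-fold higher number from compound 1 to compound 2 (0.76 log units; beyond the scatter) separates them. Compound 3 `COc1ccccc1OCC1SCCN1C(=O)CC(=O)NCc1ccncc1` has not yet been measured in this assay. Compound 3 differs from compound 2 in one place: pyridin-4-yl in place of pyridin-2-yl on a saturated chain carbon bound to an amide-type nitrogen. Among the measured compounds shown here, the single measured step, a 5.8-fold higher number from compound 1 to compound 2 (0.76 log units; beyond the scatter), alters the group on the carbonyl carbon and not the pyridinyl ring itself, so it does not bear on this change; no measured pair sets pyridin-4-yl against pyridin-2-yl. Without such a comparison, the expected step in this assay is none beyond the scatter, no change at the digits printed from compound 2 to compound 3 (within the scatter), in either direction. Compound 3 is accordingly estimated at 64 mg/kg, with a deliberately wide range from 25 mg/kg to 160 mg/kg.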

Compound 3, dose for half-maximal effect: 13 mg/kg
Compound 3: middle estimate off by 4.9-fold (0.69 log units), on the high side, and the stated range ends above it.
By their numbers in this assay, from the lowest: compounds 1 and 3 (each within the scatter of the next); then compound 2.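

In this assay the swap of pyridin-2-yl for pyridin-4-yl on the saturated chain carbon bound to an amide-type nitrogen gives a 4.9-fold lower number from compound 2 to compound 3 (0.69 log units; beyond the scatter) with the same atoms joined differently, so this position is sensitive to the attachment of the pyridine ring and not only to its composition. The step of a 1.2-fold higher number from compound 1 to compound 3 (0.07 log units; within the scatter) shows that ((pyridin-4-yl)methyl)amino can stand in place of ethoxy on the carbonyl carbon without a change beyond the scatter, so the higher number of compound 2 does not hold for every pyridinylmethyl amide. No measurement available here explains the difference between the two pyridine isomers.

On these data alone, how pyridin-3-yl or a plain phenyl would read at this position remains open. Also open, as far as these compounds go, is whether a longer chain between the amide nitrogen and pyridin-4-yl would keep the number of compound 3.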